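Aminocyclohexyl Thioether Replaces Guanidine Side Chain

The source may hold more compounds than are shown below. What is called first, only, known or untested is meant among the compounds shown, and "the series" means these compounds.

Measured so far:
compound 1, `CC(C)c1n[nH]c2c(NCc3ccc(-c4ccccn4)cc3)nc(SCC(O)CN)nc12`: 55 nM
compound 2, `CC(C)c1n[nH]c2c(NCc3ccc(-c4ccccn4)cc3)nc(SCCNC(=N)N)nc12`: 390 nM
compound 3, `CC(O)CSc1nc(NCc2ccc(-c3ccccn3)cc2)c2[nH]nc(C(C)C)c2n1`: 62 nM

Compound 2 gives the highest number of the three in a functional assay on HT cells (Homo sapiens) for antiproliferative activity, read by fluorescence, with a stated time of 72 h; a lower number here means a stronger inhibitor of growth, a higher number a weaker inhibitor of growth; its nearest neighbour is compound 3, with a 6.3-fold lower number from compound 2 to compound 3 (0.80 log units; beyond the scatter), and compound 1 lies further off, with a 7.1-fold higher number from compound 1 to compound 2 (0.85 log units; beyond the scatter). Compound 4, `CC(C)c1n[nH]c2c(NCc3ccc(-c4ccccn4)cc3)nc(SC3CCCCC3N)nc12`, differs from compound 2 at the same side chain: a group of 7 heavy atoms (6 carbon, 1 nitrogen; one six-membered non-aromatic ring of carbon only) in place of a group of 6 heavy atoms (3 carbon, 3 nitrogen; no ring), on a sulfur. Both measured steps at this position are modest and point in the same direction: swapping the group of 6 heavy atoms (3 carbon, 3 nitrogen; no ring) for another group gave lower numbers, and compound 4 keeps a nitrogen, as compound 1 does. A lower number is therefore expected, roughly a 4.9-fold lower number from compound 2 to compound 4 (0.69 log units; beyond the scatter). Compound 4 is estimated at 80 nM, within 30 nM to 300 nM.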

Compound 4, concentration for 50% growth inhibition: 139 nM
Beside the measured number, compound 4's estimate is 1.7-fold (0.24 log units) below it; the range from low to high includes it.
By their numbers in this assay, from the lowest: compounds 1 and 3 (each within the scatter of the next); then compound 4; then compound 2.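

A ring can stand on this sulfur: in this assay 2-aminocyclohexyl improves on the open chain of compound 2 (a 2.8-fold lower number from compound 2 to compound 4 (0.45 log units; beyond the scatter)). It does not reach the hydroxyl-bearing chains, however, falling short of 2-hydroxypropyl (a 2.2-fold higher number from compound 3 to compound 4 (0.35 log units; beyond the scatter)) and of 3-amino-2-hydroxypropyl (a 2.5-fold higher number from compound 1 to compound 4 (0.40 log units; beyond the scatter)). No available evidence explains these gaps.

The compounds shown leave open whether the amine on the ring contributes at all, which plain cyclohexyl would test. They also leave open whether 2-hydroxycyclohexyl would match the open hydroxyl-bearing chains.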